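Chain-shortened, branched analogue of compound 1 at the muscarinic read-out

The source may report more compounds than this note shows. Statements on the series, on what has been measured and on what is new or still open speak of the compounds shown alone.

Compound 1 `Cc1nccn1CCCC(C(N)=O)(c1ccccc1)c1ccccc1` gives 1.14 nM in an assay on ileum with muscarinic acetylcholine receptor M3 (Cavia porcellus) as the target (on this read-out higher numbers stand for weaker inhibition and lower numbers for stronger inhibition), the lowest number of the three measured. Lengthening its chain by one carbon, compound 2 `Cc1nccn1CCCCC(C(N)=O)(c1ccccc1)c1ccccc1` gives 43.7 nM in this assay, and by two carbons, compound 3 `Cc1nccn1CCCCCC(C(N)=O)(c1ccccc1)c1ccccc1` gives 71.3 nM in this assay; the steps are a 38-fold higher number from compound 1 to compound 2 (1.58 log units; beyond the scatter) and a 63-fold higher number from compound 1 to compound 3 (1.80 log units; beyond the scatter), while a 1.6-fold higher number from compound 2 to compound 3 (0.21 log units; within the scatter) lies within the scatter.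

Compound 4 `Cc1nccn1C(C)CC(C(N)=O)(c1ccccc1)c1ccccc1` is not yet measured. It differs from compound 1 by 1-(2-methyl-1H-imidazol-1-yl)ethyl in place of 2-(2-methyl-1H-imidazol-1-yl)ethyl on a saturated chain carbon, two bonds along the chain from two aromatic carbons and a carbonyl carbon; the two have the same atoms, joined differently, so the chain is one carbon shorter and carries a methyl branch. Among the measured compounds shown here, no measured step covers a shortened or branched chain; the two measured steps both move away from compound 1 and both weaken binding, so compound 1 seems to sit at a favourable chain length. Any departure from it is therefore expected to cost, and a moderately higher number is estimated for compound 4, about 12 nM, with a range of 2 nM to 70 nM, which would mean a step of an 11-fold higher number from compound 1 to compound 4 (1.02 log units; beyond the scatter).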

Compound 4, antagonist equilibrium constant: 16.9 nM
Estimate against measurement, compound 4: 1.4-fold (0.15 log units) below, within the range that was stated.
By their numbers in this assay, from the lowest: compound 1; then compound 4; then compounds 2 and 3 (each within the scatter of the next).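

Replacing 2-(2-methyl-1H-imidazol-1-yl)ethyl with 1-(2-methyl-1H-imidazol-1-yl)ethyl leaves the atoms unchanged yet gives a 15-fold higher number from compound 1 to compound 4 (1.17 log units; beyond the scatter) in this assay, so at this position the way the chain is joined matters, not only what it contains. The earlier steps shown here only lengthened the chain; this one shows that a shorter, branched chain also gives a higher number, and compound 1 remains the lowest of the four. No measurement in hand explains the loss of binding.

Still open, going by these compounds, is which part of the change drives the step, the shorter chain or the methyl branch; (2-methyl-1H-imidazol-1-yl)methyl at this position would help separate the two. Also open, on these data alone, is how a tertiary amine in place of 2-methyl-1H-imidazol-1-yl, or a carboxylic acid in place of the primary amide, would read.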